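Methylating a Ring Hydroxyl on Two Related Cores

The source may hold more compounds than are shown below. What is called first, only, known or untested is meant among the compounds shown, and "the series" means these compounds.

Compound 1, `COc1cc2nccc(O)c2c(O)c1OC`, and compound 2, `COc1cc2nccc(O)c2c(OC)c1OC`, share one core. Compound 3, `COc1cc2c(c(O)c1OC)c(=O)ccn2C`, is built on another core, and the difference between the two cores is not broken down here. Compound 4, `COc1cc2c(c(OC)c1OC)c(=O)ccn2C`, has not yet been measured.

In a functional assay on L1210 cells (Mus musculus) for antiproliferative activity (on this read-out higher numbers stand for weaker inhibition and lower numbers for stronger inhibition), compound 1 gives only a limit of the assay, > 40000 nM. Compound 2 likewise gives only a limit, > 40000 nM. Compound 3 also gives only a limit, > 40000 nM. The step that the two limits leave unreadable from compound 1 to compound 2 therefore cannot be read, although the change itself is clear: methyl in place of hydrogen on an oxygen on an aromatic ring.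

The change planned from compound 3 to compound 4 is the same: methyl in place of hydrogen on an oxygen on an aromatic ring. Within the data shown here, the step from compound 3 to compound 4 is expected to be a step that the limit leaves unreadable from compound 3 to compound 4, because the three measured values sit at the limit of > 40000 nM in this assay, at which 3 of the 3 values shown sit, and the one earlier example of this change stayed at that limit. Compound 4 is accordingly expected to give about 60000 nM, most likely again only a limit, with a range from 20000 nM to 200000 nM.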

Compound 4, half-maximal inhibitory concentration: > 40000 nM
Compound 4: only a limit was reported (the forecaster's own chance of this, stated with the estimate: 85%); the middle value does not contradict the limit.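

No new step can be read, because compound 3 and compound 4 both stop at the same limit of the assay, as do the two other compounds: the limit of > 40000 nM in this assay, at which 4 of the 4 values shown sit. The compounds shown leave open whether changing hydroxy to methoxy alters activity at all in this assay, and which structural change would bring a value within the measurable range.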